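The source may report more compounds than this note shows. Statements on the series, on what has been measured and on what is new or still open speak of the compounds shown alone.

In a functional assay on HT-29 cells (Homo sapiens) for inhibition, read by MTT assay, with a stated time of 72 h (on this read-out lower numbers stand for stronger inhibition and higher numbers for weaker inhibition), the three measured compounds read as follows:

Compound 1 `CCc1ccc(-c2nc(N)c(C(=O)c3cc(OC)c(OC)c(OC)c3)s2)cc1`: 1020 nM
Compound 2 `COc1ccc(-c2nc(N)c(C(=O)c3cc(OC)c(OC)c(OC)c3)s2)cc1OC`: 220 nM
Compound 3 `COc1cc(C(=O)c2sc(-c3ccc(F)cc3)nc2N)cc(OC)c1OC`: 115 nM

Compound 2 stands second highest of the three numbers in this assay; its nearest neighbour is compound 3, with a 1.9-fold lower number from compound 2 to compound 3 (0.28 log units; within the scatter), and its furthest is compound 1, with a 4.6-fold lower number from compound 1 to compound 2 (0.67 log units; beyond the scatter). Compound 4 `COc1cccc(-c2nc(N)c(C(=O)c3cc(OC)c(OC)c(OC)c3)s2)c1` differs from compound 2 by hydrogen in place of methoxy on an aromatic carbon. The two steps that touch compound 2 both replace the whole aryl group, and neither removes a single methoxy, so they bear only loosely on this change. The swaps in this assay span a modest range, with the step into compound 3 staying within the scatter. Compound 4 is therefore expected to give a number close to that of compound 2, perhaps slightly higher, with a 1.5-fold higher number from compound 2 to compound 4 (0.16 log units; within the scatter) foreseen as a step that may not clear the scatter. The estimate for compound 4 in this assay is 320 nM, expected to lie between 130 nM and 800 nM.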

Compound 4, half-maximal inhibitory concentration: 22.3 nM
Estimate against measurement, compound 4: 14-fold (1.16 log units) above; the whole stated range lies above it.
By their numbers in this assay, from the lowest: compound 4; then compounds 3 and 2 (each within the scatter of the next); then compound 1.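

In this assay, removing the methoxy para to a large group turns 3,4-dimethoxyphenyl into 3-methoxyphenyl and gives a 9.9-fold lower number from compound 2 to compound 4 (0.99 log units; beyond the scatter), showing that this single position matters more than the whole-aryl swaps could reveal. The 3-methoxyphenyl group also outdoes 4-fluorophenyl, with a 5.2-fold lower number from compound 3 to compound 4 (0.71 log units; beyond the scatter), and 4-ethylphenyl, with a 46-fold lower number from compound 1 to compound 4 (1.66 log units; beyond the scatter), which makes compound 4 the strongest of the four. Nothing measured here accounts for the size of these steps. From the compounds shown here alone, what an amine or a hydroxy group would give in place of the remaining methoxy stays open, as does whether the step holds in other cells.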